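This account rests on a few compounds, and the source may have more. Where it says the series, first, only, none or still open, it means among the compounds named here.

Measured in a functional assay on PANC-1 cells (Homo sapiens) for cytotoxicity, read by CellTiter-Glo, with a stated time of 72 h; on this read-out lower numbers stand for stronger inhibition and higher numbers for weaker inhibition:
- compound 1 `C=C1C(=O)C2=C3[C@@H](CC[C@H]4C(=C)C(=O)O[C@@H]4[C@@H]13)CC[C@]21C(=O)C[C@H]2C(=C)CC[C@H]3C(=C)C(=O)O[C@@H]3[C@H]21`: > 10000 nM (a limit)
- compound 2 `C=C1C(=O)O[C@@H]2[C@@H]3C4=C(C(=O)[C@H]3CO)[C@]3(CC[C@]4(O)CC[C@@H]12)C(=O)C[C@H]1C(=C)CC[C@H]2C(=C)C(=O)O[C@@H]2[C@H]13`: > 10000 nM (a limit)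
- compound 3 `C=C1C(=O)C2=C3[C@H]1[C@H]1OC(=O)C(=C)[C@@H]1CC[C@@]3(O)CC[C@]21C(=O)C[C@H]2C(=C)CC[C@H]3C(=C)C(=O)O[C@@H]3[C@H]21`: 5400 nM

Among the compounds with values here, compound 3 gives 5400 nM, the only actual number in this small set. The other two results are limits of this assay, not numbers.

Compound 4 `C=C1C(=O)C2=C3[C@H]1[C@H]1OC(=O)C(=C)[C@@H]1CC[C@]3(O)CC[C@]21C(=O)C[C@H]2C(=C)CC[C@H]3C(=C)C(=O)O[C@@H]3[C@H]21` is related to compound 3 by a single change: the two compounds have the same atoms and bonds and differ only in configuration as drawn: 1 of 9 stereo elements differ; a stereocentre at a saturated ring carbon is drawn R in compound 3 and S in compound 4. Such a change can matter in a cell assay, or it can matter very little. Within the data shown here, no two measured compounds differ in one place only, so the data do not show how large a single change tends to be here.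

The expectation therefore rests on compound 3 at 5400 nM, with no shift beyond the usual scatter in either direction. The expected step of a 1.1-fold higher number from compound 3 to compound 4 (0.05 log units; within the scatter) is correspondingly small. A result reported only as a limit would be no surprise, given (the limit of > 10000 nM in this assay, at which 2 of the 3 values shown sit).

For compound 4 the estimated value is 6000 nM, with an expected range from 2000 nM to 10000 nM.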

Compound 4, half-maximal inhibitory concentration: 2200 nM
Compound 4: middle estimate off by 2.7-fold (0.44 log units), on the high side; the measured number falls inside the stated range.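

In this assay the result is a 2.5-fold lower number from compound 3 to compound 4 (0.39 log units; beyond the scatter), and this step can be traced to the one stereocentre alone, because nothing else separates the pair: the fact that compounds 3 and 4 differ only in the configuration as drawn

Replacing one substituent also matters, since hydroxy in place of hydrogen on a saturated ring carbon gives an at least 4.5-fold lower number from compound 1 to compound 4 (0.65 log units; beyond the scatter). Compound 1 sits at > 10000 nM, which is a limit of the assay and not a number.

The compounds shown leave open whether a methoxy group or an amine on that carbon would give a lower or a higher number than the hydroxy group. They also leave open whether the drawn S configuration would still give the lower number with such a group in place.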